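A few compounds are considered here, and "the series" means these few. Any claim that something is new, unique, unknown or untested is made for them only; others in the source may bear on it.

In a functional assay on KB cells (Homo sapiens) for antiproliferative activity, read by colorimetric assay and MTT assay (a higher number here means a weaker inhibitor, a lower number a stronger inhibitor), compound 1 `COc1ccc(S(=O)(=O)Nc2cccc3cc[nH]c23)cc1` gives 0.67 ug/mL and compound 2 `COc1ccc(S(=O)(=O)Nc2cccc3cc(O)[nH]c23)cc1` gives 0.1 ug/mL, which leaves compound 1 with the higher, weaker number of the two. Compound 3 `O=[N+]([O-])c1ccc(S(=O)(=O)Nc2cccc3cc[nH]c23)cc1` has not yet been measured. It differs from compound 1 at one place: nitro in place of methoxy on an aromatic carbon. In words, nitro takes the place of methoxy on an aromatic carbon, para to a large group. Among the compounds with values here, the only measured step is a 6.7-fold lower number from compound 1 to compound 2 (0.83 log units; beyond the scatter), and it comes from hydroxy in place of hydrogen on an aromatic carbon. That is a different change at a different place, so it gives no direction for nitro, only a sense of how far one change can move this assay. No larger move than that is expected here, and the direction stays uncertain. The estimated step is a 1.3-fold higher number from compound 1 to compound 3 (0.13 log units; within the scatter). For compound 3 the expected value is 0.9 ug/mL, within an estimated range from 0.2 ug/mL to 4 ug/mL.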

Compound 3, half-maximal inhibitory concentration: 15 ug/mL
Compound 3: the middle estimate sits 17-fold (1.22 log units) below what was measured; measured number above the stated range.
By their numbers in this assay, from the lowest: compound 2; then compound 1; then compound 3.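

In this assay, nitro in place of methoxy gives a 22-fold higher number from compound 1 to compound 3 (1.35 log units; beyond the scatter), so the aromatic carbon para to a large group has a strong influence on this read-out, and this change makes the compound a weaker inhibitor. The earlier step, a 6.7-fold lower number from compound 1 to compound 2 (0.83 log units; beyond the scatter), came from a change at a different place and went towards a stronger inhibitor, so changes to compound 1 can move the number in either direction. Nothing available explains why nitro gives this result.

As far as these compounds go, with only methoxy and nitro compared at this place, it remains open whether the loss is particular to nitro or would follow from removing methoxy. From the compounds shown here alone, how an amine or a methyl group would read at the same carbon is also open.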